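Swapping a Chain-End Nitrile for a Carboxylic Acid

The source may report more compounds than this note shows. Statements on the series, on what has been measured and on what is new or still open speak of the compounds shown alone.

Measured so far:
compound 1, `COCc1cc(C(C)=O)c(O)cc1OCCCCCCC#N` — 47%
compound 2, `CCc1cc(C(C)=O)c(O)cc1OCCCCCCC(C)(C)C#N` — 65%

Both compounds were tested in an assay on isolated protein for inhibition of leukotriene B4 receptor 1 (Homo sapiens), tested at 10 uM; a higher number here means more inhibition at the concentration tested (going by the name of the read-out), a lower number less inhibition. Among the measured compounds shown here, compound 2 gives the higher of the two numbers, 65%, and compound 1 is the only other measured compound; its value, 47%, lies beyond the scatter below it. The two structures differ in more than one place, so no single change can be tied to that gap.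

The next compound, compound 3 `CCc1cc(C(C)=O)c(O)cc1OCCCCCCC(=O)O`, shares the core and the chain of compound 2 but carries a different group at the end of the chain: carboxy in place of 1-cyano-1-methylethyl on a saturated chain carbon, six bonds along the chain from an oxygen on an aromatic ring. For the measured compounds named here, no pair of measured compounds shows this change or anything close to it, so there is no measured step to lean on.

With no guide from the data, the expectation for this assay is a step from compound 2 to compound 3 of no clear direction, most likely within the scatter, and a number 10 percentage points lower from compound 2 to compound 3 (within the scatter) is the estimated change. Compound 3 is therefore expected to give about 55%, within a range from 25% to 85%.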

Compound 3, a percentage reported as inhibition, at one concentration (the size of the read-out at that concentration, not a potency): 87%
Estimate against measurement, compound 3: 32 percentage points below, outside the stated range (above it).
By their numbers in this assay, from the lowest: compound 1; then compound 2; then compound 3.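

The end of the chain, six bonds along from an oxygen on an aromatic ring, turns out to matter in this assay: with the shared core and the saturated chain left alone, putting carboxy in place of 1-cyano-1-methylethyl gives a number 22 percentage points higher from compound 2 to compound 3 (beyond the scatter). Among the compounds shown here, this is the first comparison where only one place differs, so this gap, unlike the earlier one, can be tied to a single change. The entering group is the smaller of the two, with 3 heavy atoms against 5, and it brings a hydrogen-bond donor that the leaving group lacks, but nothing shown gives a measured reason for the rise.

The swap removes the nitrile and the two methyl groups and adds the carboxy all at once, so these compounds cannot tell whether the rise comes from losing the old group or gaining the new one. Also open, going by these compounds, is whether a methyl ester or a primary amide at the chain end would hold the number, and whether a shorter or longer chain carrying the carboxy would do the same.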